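The compounds below may be only part of what the source reports. "The series", "measured", "known", "first", "only" and "open" are said of these compounds alone.

Compound 1 `Cc1cc2c(cc1Cc1ccc(C(=O)NCc3ccc(CN)cc3)o1)C(C)(C)CCC2(C)C` and compound 2 `Cc1cc2c(cc1Cc1ccc(C(=O)NCc3ccccc3)o1)C(C)(C)CCC2(C)C` share one core and differ in a single place. In an assay on isolated protein for binding affinity to Gonadotropin-releasing hormone receptor (Rattus norvegicus) (a lower number here means a stronger inhibitor, a higher number a weaker inhibitor), compound 1 gives 280 nM, and compound 2 gives 240 nM; the two numbers sit together, since a 1.2-fold lower number from compound 1 to compound 2 (0.07 log units; within the scatter). Compound 3 `Cc1cc2c(cc1Cc1ccc(C(=O)NCC3CCC(CN)CC3)o1)C(C)(C)CCC2(C)C` carries 4-(aminomethyl)cyclohexyl in place of phenyl on a saturated chain carbon bound to an amide-type nitrogen. Among the compounds with values here, only that one step bears on this change, and it shows that an aminomethyl group on an aromatic carbon left the number unchanged within the scatter. Compound 3 is therefore expected to reach 300 nM, between 120 nM and 800 nM. That amounts to an expected step of a 1.3-fold higher number from compound 2 to compound 3 (0.10 log units; within the scatter), none beyond the scatter.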

Compound 3, inhibition constant: 730 nM
For compound 3 the middle estimate is 2.4-fold (0.39 log units) below the measured one, within the range that was stated.
By their numbers in this assay, from the lowest: compounds 2 and 1 (each within the scatter of the next); then compound 3.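

In this assay the ring itself matters at this position, where the aminomethyl group on the aromatic ring had made no clear difference. With the aminomethyl group kept, changing the aromatic ring to a cyclohexyl ring gives a 2.6-fold higher number from compound 1 to compound 3 (0.42 log units; beyond the scatter) and so weakens binding, and replacing plain phenyl with 4-(aminomethyl)cyclohexyl gives a 3.0-fold higher number from compound 2 to compound 3 (0.48 log units; beyond the scatter) in the same direction. No measurement at hand explains this shift. Still open, from the compounds shown here alone, is whether the aminomethyl group counts on the saturated ring, as a plain cyclohexyl group would show, and whether a carboxylic acid or longer chain there would behave alike.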